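Swapping a pyrimidine for phenyl in a PEO1 cell series

A few compounds are considered here, and "the series" means these few. Any claim that something is new, unique, unknown or untested is made for them only; others in the source may bear on it.

Compound 3 `CC(Sc1nc2c(cnn2C)c(=O)n1-c1ccccc1)c1cncnc1` gives 39% in an assay on PEO1 cells for inhibition of Retinaldehyde dehydrogenase 3 (Homo sapiens), read by flow cytometry, with a stated time of 30 min, tested at 1 uM; on this read-out higher numbers stand for more inhibition at the one concentration tested (going by the name of the read-out) and lower numbers for less inhibition. Going by the values given here, on the three numbers known, compound 3 stands second highest: compound 1 `CC(Sc1nc2c(cnn2C)c(=O)n1-c1ccccc1)c1cccnc1` gives 95%, and compound 2 `Cn1ncc2c(=O)n(-c3ccccc3)c(SCc3cccc(F)c3)nc21` gives 3%. Compound 4 `CC(Sc1nc2c(cnn2C)c(=O)n1-c1ccccc1)c1ccccc1` has not been measured. It differs from compound 3 in one place: phenyl in place of pyrimidin-5-yl on a saturated chain carbon bound to a saturated chain carbon and a sulfur. The step that bears most on this is a number 56 percentage points lower from compound 1 to compound 3 (beyond the scatter), where the pyridin-3-yl ring was exchanged for a pyrimidin-5-yl ring on the same saturated chain carbon; phenyl now moves the ring in the other direction, away from any hetero atom. The other carbocyclic ring in the set, the 3-fluorobenzyl of compound 2, gave a number 36 percentage points higher from compound 2 to compound 3 (beyond the scatter), which points the opposite way, though that change also altered the chain. Weighing both, a moderate rise is expected, a number 11 percentage points higher from compound 3 to compound 4 (beyond the scatter), with wide uncertainty. Compound 4 is therefore estimated at 50%, within 10% to 85% in this assay.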

Compound 4, a percentage reported as inhibition, at one concentration (the size of the read-out at that concentration, not a potency) in the Retinaldehyde dehydrogenase 3 assay: 47%
For compound 4 the middle estimate is 3 percentage points above the measured one; the range from low to high includes it.
By their numbers in the Retinaldehyde dehydrogenase 3 assay, from the lowest: compound 2; then compounds 3 and 4 (each within the scatter of the next); then compound 1.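

In the Retinaldehyde dehydrogenase 3 assay, the change to phenyl on this saturated chain carbon gives a number 8 percentage points higher from compound 3 to compound 4 (within the scatter), so taking both nitrogens out of the ring does not separate these two compounds, while the pyridin-3-yl ring still stands apart, with a number 48 percentage points lower from compound 1 to compound 4 (beyond the scatter). A ring of carbon only does not by itself give a number as low as that of compound 2, since 1-phenylethyl in place of 3-fluorobenzyl on the sulfur gives a number 44 percentage points higher from compound 2 to compound 4 (beyond the scatter). The same pyrimidin-5-yl to phenyl change that leaves inhibition within the scatter does separate the two compounds in a physicochemical assay for solubility, using the shake flask method, in phosphate buffer, with a stated time of 24 h, at pH 7.4 (on this read-out higher numbers stand for higher solubility and lower numbers for lower solubility), where compound 3 gives 264000 nM and compound 4 gives 8000 nM: the measured solubility of compound 3, 264000 nM, and of compound 4, 8000 nM, a 33-fold lower number (1.52 log units; beyond the scatter)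

On these data alone, that last inhibition step changes the ring substituent and the chain together, so which of them carries it remains open. Also open, as far as these compounds go, is whether pyridin-4-yl in this place would give a number in the Retinaldehyde dehydrogenase 3 assay closer to compound 1 or to compound 4.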